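This account rests on a few compounds, and the source may have more. Where it says the series, first, only, none or still open, it means among the compounds named here.

Compound 3 `COc1cc(-c2nn(-c3cccc(NC(=O)Nc4ccc(Cl)c(C(F)(F)F)c4)c3)cc2-c2ccncc2)ccc1Cl` is the reference point of this account. In a functional assay on RPMI-8226 cells (Homo sapiens) for inhibition, read by sulforhodamine B assay, with a stated time of 48 h (on this read-out lower numbers stand for stronger inhibition of growth and higher numbers for weaker inhibition of growth), compound 3 gives 3250 nM. Compound 1 `COc1cc(-c2nn(-c3cccc(NC(=O)Nc4ccc(Cl)c(Cl)c4)c3)cc2-c2ccncc2)ccc1Cl` gives 3260 nM in this assay, and the step of a 1.0-fold lower number from compound 1 to compound 3 (0.00 log units; within the scatter) leaves the two indistinguishable. Compound 2 `COc1cc(-c2nn(-c3cccc(NC(=O)c4ccc(Cl)c(C(F)(F)F)c4)c3)cc2-c2ccncc2)ccc1Cl` returns only a limit in this assay, > 32500 nM, so of the three results two are numbers and one is a limit (the limit of > 32500 nM in this assay, at which 1 of the 3 values shown sits).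

Compound 4 `COc1cc(-c2nn(-c3cccc(NC(=O)c4ccccc4)c3)cc2-c2ccncc2)ccc1Cl` has not been measured. It differs from compound 3 by phenyl in place of (4-chloro-3-(trifluoromethyl)phenyl)amino on a carbonyl carbon. The urea-to-amide change at the same carbonyl carbon has been seen twice: the step of an at least 9.9-fold higher number from compound 1 to compound 2 (0.99 log units; beyond the scatter) and its reverse at least 10-fold lower number from compound 2 to compound 3 (1.00 log units; beyond the scatter), both beyond the scatter. Compound 4 carries the same amide linkage as compound 2, though with an unsubstituted phenyl, so a step in the same direction is expected, most likely again reaching the limit of this assay.

For compound 4 the expected step is an 11-fold higher number from compound 3 to compound 4 (1.03 log units; beyond the scatter), and the estimate in this assay is 35000 nM, within a range from 10000 nM to 120000 nM.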

Compound 4, concentration for total growth inhibition: > 100000 nM
Compound 4 gave a limit, no number (the forecaster's own chance of this, stated with the estimate: 65%); middle value at least 2.8-fold (0.45 log units) away from the limit.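

In this assay, putting phenyl on the carbonyl carbon in place of the substituted arylamino group gives an at least 30-fold higher number from compound 3 to compound 4 (1.48 log units; beyond the scatter), and the same change from the dichloro urea gives an at least 30-fold higher number from compound 1 to compound 4 (1.48 log units; beyond the scatter), so both ureas stand clearly apart from this unsubstituted amide. Compound 4 gives only a limit, not a number: the limit of > 100000 nM in this assay, at which 1 of the 4 values shown sits. Compound 2, the amide that keeps the chloro and trifluoromethyl substituents, also gives only a limit, so the step between these two amides cannot be read and the substituents show no readable effect on the amide series.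

The compounds shown leave open whether the urea nitrogen or the substituents on the terminal phenyl matter more for the numbers seen with the ureas. A phenylamino group on the same carbonyl carbon would separate the two, and a benzylamino group would test a longer link.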